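Compound 1 to compound 4: a methoxyphenyl exchange

A few compounds are considered here, and "the series" means these few. Any claim that something is new, unique, unknown or untested is made for them only; others in the source may bear on it.

Measured so far (a functional assay on the whole organism (strain Kunming) with Mus musculus as the target, with a stated time of 0.5 h; on this read-out higher numbers stand for an effect only at larger amounts of compound and lower numbers for an effect already at smaller amounts)
- compound 1 `COc1ccccc1/C=C/C(=O)OC/C=C/c1cc(OC)c(OC)cc1OC` gives 625 umol/kg as a number
- compound 2 `COc1cc(OC)c(OC)cc1/C=C/COC(=O)/C=C/c1ccc(OC)c(OC)c1` gives 418 umol/kg as a number
- compound 3 `COc1cc(OC)c(OC)cc1/C=C/COC(=O)/C=C/c1ccccc1C(F)(F)F` gives > 473 umol/kg as a limit of the assay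

For the measured compounds named here, compound 1 stands within the scatter of compound 2, the only other number, with a 1.5-fold lower number from compound 1 to compound 2 (0.17 log units; within the scatter) between them. Compound 3 stands at the limit of > 473 umol/kg in this assay, at which 1 of the 3 values shown sits, and leaves a step that the limit leaves unreadable from compound 1 to compound 3 in this series. Compound 4 `COc1ccc(/C=C/C(=O)OC/C=C/c2cc(OC)c(OC)cc2OC)cc1` differs from compound 1 by 4-methoxyphenyl in place of 2-methoxyphenyl on a double-bonded chain carbon bound to a double-bonded chain carbon in its structure. The nearest guide is the exchange at that same place, a 1.5-fold lower number from compound 1 to compound 2 (0.17 log units; within the scatter) and no more. an at least 1.1-fold higher number from compound 2 to compound 3 (0.05 log units; that floor lies within the scatter) also shows no step beyond the scatter. No step beyond the scatter is therefore expected in this assay for this change, and the estimate is a 1.3-fold lower number from compound 1 to compound 4 (0.10 log units; within the scatter) at most. For compound 4 the expected value is 500 umol/kg with an estimated range of 250 umol/kg to 1000 umol/kg overall.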

Compound 4, dose for half-maximal effect: 634 umol/kg
Estimate against measurement, compound 4: 1.3-fold (0.10 log units) below; the range from low to high includes it.
By their numbers in this assay, from the lowest: compounds 2, 1 and 4 (each within the scatter of the next).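

In this assay, 4-methoxyphenyl in place of 2-methoxyphenyl on a double-bonded chain carbon bound to a double-bonded chain carbon gives a 1.0-fold higher number from compound 1 to compound 4 (0.01 log units; within the scatter), so this exchange of two groups with the same atoms leaves the read-out within the scatter. Hydrogen in place of methoxy on an aromatic carbon gives a 1.5-fold higher number from compound 2 to compound 4 (0.18 log units; within the scatter), also within the scatter. Compound 3 stands at a limit, so its step to compound 4 cannot be read: the limit of > 473 umol/kg in this assay, at which 1 of the 4 values shown sits.

No step beyond the scatter appears at this place among the readable pairs. On these data alone, whether an amine or a carboxylic acid on this phenyl would give one stays open.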